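Dichloro substitution on the urea phenyl of compound 2

This account rests on a few compounds, and the source may have more. Where it says the series, first, only, none or still open, it means among the compounds named here.

Measured compounds:
- Compound 1 `Cc1ccc(NC(=O)Nc2ccc(-c3nc(NCCN(C)C)c4sccc4n3)cc2)cc1` gives 2150 nM in a functional assay on HT-29 cells (Homo sapiens) for cytotoxicity, read by MTT assay, with a stated time of 72 h; on this read-out higher numbers stand for weaker inhibition and lower numbers for stronger inhibition
- Compound 2 `CCN(CC)CCCNc1nc(-c2ccc(NC(=O)Nc3ccccc3)cc2)nc2c(Cl)c(Cl)sc12` gives 820 nM in this assay

Of the two numbers in hand, compound 2 holds the lower one, and the gap between compound 2 and compound 1 lies beyond the usual scatter of this assay. Compound 1 and compound 2 differ in more than one place, so their gap cannot be tied to a single change.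

Compound 3 `CCN(CC)CCCNc1nc(-c2ccc(NC(=O)Nc3ccc(Cl)cc3Cl)cc2)nc2c(Cl)c(Cl)sc12` differs from compound 2 in one place only: 2,4-dichlorophenyl in place of phenyl on an amide-type nitrogen. Nothing in the measured pair speaks directly to this change, so the expectation rests on the change itself and on the value of compound 2 alone. A modest step in this assay , towards a lower number, is expected for compound 3, about a 1.6-fold lower number from compound 2 to compound 3 (0.21 log units; within the scatter), though a step within the scatter would not surprise. Compound 3 is therefore estimated at 500 nM, with a range from 200 nM to 1500 nM.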

Compound 3, half-maximal inhibitory concentration: 1230 nM
Compound 3: middle estimate off by 2.5-fold (0.39 log units), on the low side, and the stated range covers the measured number.
By their numbers in this assay, from the lowest: compounds 2, 3 and 1 (each within the scatter of the next, the first and the last beyond it).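

Within the data shown here, this is the first comparison in which only one place changes, and it concerns the outer ring of the urea. In this assay, 2,4-dichlorophenyl in place of phenyl on an amide-type nitrogen gives a 1.5-fold higher number from compound 2 to compound 3 (0.18 log units; within the scatter) so compound 2 and compound 3 cannot be told apart in this read-out. At this position, then, the two chlorine atoms bring no clear gain or loss in cytotoxicity, and no accompanying measurement offers an explanation for this result.

From the compounds shown here alone, whether a single chlorine, a methoxy group or a carboxylic acid on this ring would shift the number beyond the scatter remains open. Compound 1 differs from compound 2 and compound 3 in more than one place, so it cannot settle this question.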